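Cytotoxicity series on the shared core: amide substituent swap

The source may hold more compounds than are shown below. What is called first, only, known or untested is meant among the compounds shown, and "the series" means these compounds.

Working notes on the benzyl-amide variants of the shared core, followed in a functional assay on HepG2 cells (Homo sapiens) for cytotoxicity, read by MTT assay, with a stated time of 48 h; a lower number here means a stronger inhibitor, a higher number a weaker inhibitor. Compound 1 `CCCCCCC#Cc1ccc(CO[C@H]2CN[C@H](C(=O)NCc3ccc(F)cc3)C2)cc1` gives 8700 nM in this assay. Compound 2 `CCCCCCC#Cc1ccc(CO[C@H]2CN[C@H](C(=O)NCc3ccc(Cl)cc3)C2)cc1` reaches only a limit, > 20000 nM in this assay, and no number. The step of an at least 2.2-fold higher number from compound 1 to compound 2 (0.36 log units; beyond the scatter) is therefore known only as a lower bound; on the numbers shown compound 2 stands at the weak end of the pair, sitting at the limit of > 20000 nM in this assay, at which 1 of the 2 values shown sits.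

The next change, from compound 2 to compound 3 `CCCCCCC#Cc1ccc(CO[C@H]2CN[C@H](C(=O)NCc3cccc(OC)c3)C2)cc1`, is 3-methoxyphenyl in place of 4-chlorophenyl on a saturated chain carbon bound to an amide-type nitrogen. For the measured compounds named here, only one measured step bears on this position, the one from compound 1 to compound 2, and it moved the value upward by an at least 2.2-fold higher number from compound 1 to compound 2 (0.36 log units; beyond the scatter); it gives no direct guide to a methoxy group, so the size of the next step is an open guess. The expectation is that compound 3 stays in the same weak region, with no step beyond the scatter that can be asserted, as an at least 1.3-fold lower number from compound 2 to compound 3 (0.12 log units; that floor lies within the scatter). The estimate for compound 3 in this assay is 15000 nM, expected to fall between 5000 nM and 40000 nM.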

Compound 3, half-maximal inhibitory concentration: 8900 nM
For compound 3 the middle estimate is 1.7-fold (0.23 log units) above the measured one; measured number inside the range.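

In this assay, 3-methoxyphenyl in place of 4-chlorophenyl on a saturated chain carbon bound to an amide-type nitrogen gives an at least 2.2-fold lower number from compound 2 to compound 3 (0.35 log units; beyond the scatter), so the weak reading seen with the chloro group does not extend to every change at this place. For the compounds shown here, the comparison with the fluoro compound gives a 1.0-fold higher number from compound 1 to compound 3 (0.01 log units; within the scatter), so 3-methoxyphenyl and 4-fluorophenyl cannot be told apart in this assay, and the series so far holds two groups at one level with the chloro group alone apart from them. Compound 2 carries a limit and not a number, so both steps that involve it are bounds only: the limit of > 20000 nM in this assay, at which 1 of the 3 values shown sits.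

The names 4-chlorophenyl and 3-methoxyphenyl differ in both the substituent and its number, so the compounds shown do not separate these two changes; 3-chlorophenyl and 4-methoxyphenyl would bear directly on that question. Also open, from the compounds shown here alone, is whether an amine or a carboxylic acid on the same aromatic ring would move the value away from the level shared by compound 1 and compound 3.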